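Pyridyl to carboxymethylphenyl swap on the dimethylaminopropyl amide

The compounds below may be only part of what the source reports. "The series", "measured", "known", "first", "only" and "open" are said of these compounds alone.

Measured so far in an assay on striatum for binding affinity to 5-hydroxytryptamine receptor 1D (Cavia porcellus), in the presence of a further agent that is not named here; on this read-out lower numbers stand for stronger inhibition and higher numbers for weaker inhibition:
compound 1 `COc1ccc(C(=O)Nc2ccc(-c3ccncc3)cc2)cc1CCCN(C)C` — 10 nM
compound 2 `COc1ccc(NC(=O)c2ccc(-c3ccc(C(=O)N(C)C)cc3C)cc2)cc1N1CCN(C)CC1` — 5.01 nM
compound 3 `COc1ccc(C(=O)Nc2ccc(-c3ccncc3)cc2)cc1N1CCN(C)CC1` — 3.16 nM

Compound 1 gives the highest of the three numbers in this assay. Compound 2 sits nearest to it, within the scatter, so no order between compound 1 and compound 2 can be claimed. Within the data shown here, compound 3 lies furthest, and the only single-point step in the set, a 3.2-fold lower number from compound 1 to compound 3 (0.50 log units; beyond the scatter), is modest but beyond the scatter; it concerns the amine side chain on the methoxy-bearing ring, not the far end of the biaryl.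

Compound 4 `COc1ccc(C(=O)Nc2ccc(-c3ccc(C(=O)O)cc3C)cc2)cc1CCCN(C)C` is the next candidate. Relative to compound 1 the change is 4-carboxy-2-methylphenyl in place of pyridin-4-yl on an aromatic carbon. Among the measured compounds shown here, no measured pair isolates this change. For the measured compounds named here, compound 2 carries a 2-methylphenyl bearing a dimethylcarbamoyl group at the corresponding end and gives 5.01 nM, but it differs from compound 1 in more than one place, so it offers only a loose reference; the free carboxylic acid in compound 4 has no direct precedent here. The expectation for compound 4 is therefore an uncertain one, centred on no change beyond the scatter, with the step from compound 1 to compound 4 estimated as a 1.5-fold higher number from compound 1 to compound 4 (0.18 log units; within the scatter). Compound 4 is expected to give about 15 nM, with a plausible range from 4 nM to 60 nM.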

Compound 4, inhibition constant: 31.6 nM
The estimate for compound 4 lay 2.1-fold (0.32 log units) below the measured number; the measured number falls inside the stated range.
By their numbers in this assay, from the lowest: compounds 3, 2 and 1 (each within the scatter of the next, the first and the last beyond it); then compound 4.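

This position, an aromatic carbon para to a large group, now has its first single-place step: in this assay the replacement of pyridin-4-yl by 4-carboxy-2-methylphenyl gives a 3.2-fold higher number from compound 1 to compound 4 (0.50 log units; beyond the scatter) as a modest change beyond the scatter. Until now the only single-place step in the series lay on the amine side chain, so this end of the molecule is also shown to shift the number, with compound 4 still at 31.6 nM and thus in the nanomolar range despite the loss of the ring nitrogen and the entry of the carboxylic acid. Nothing measured here bears on the reason for this shift.

The replacement brings in the carboxylic acid and the methyl group and removes the ring nitrogen in a single step, so the shares of these changes remain unresolved, and an unsubstituted phenyl, a 2-methylphenyl or a methyl ester at this position would begin to separate them. Also open, going by these compounds, is whether the same replacement gives a step of similar size with 4-methylpiperazin-1-yl in place of the 3-(dimethylamino)propyl chain.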